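The source may hold more compounds than are shown below. What is called first, only, known or untested is meant among the compounds shown, and "the series" means these compounds.

Measured so far in an ADME assay on microsomes from liver (Homo sapiens) for metabolic stability, read by LC-MS, using NADPH, with a stated time of 60 min; on this read-out lower numbers stand for a less stable compound and higher numbers for a more stable compound
Compound 1 `CC(C)(C)c1cc2c(Oc3ccccc3F)ncnc2s1` gives 61%
Compound 2 `CC(C)(C)c1sc2ncnc(Oc3ccccc3F)c2c1-c1ccccc1` gives 78%

Among the compounds with values here, compound 2 holds the higher of the two numbers so far. Compound 3 `CC(C)(C)c1sc2ncnc(Oc3ccccc3F)c2c1-c1ccc(F)cc1` alters it in one place, (fluoro in place of hydrogen on an aromatic carbon), with fluoro in place of hydrogen on an aromatic carbon, para to a large group. Within the data shown here, the one measured step, a number 17 percentage points higher from compound 1 to compound 2 (beyond the scatter), is modest and put in phenyl rather than fluoro, so it is only a loose guide, and no shift beyond the scatter is expected for compound 3. The expected step is small: a number 2 percentage points higher from compound 2 to compound 3 (within the scatter). For compound 3 the estimated value is 80%, with an expected range from 66% to 92%.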

Compound 3, percent of the compound remaining: 88%
Compound 3: the middle estimate sits 8 percentage points below what was measured, and the stated range covers the measured number.
By their numbers in this assay, from the lowest: compound 1; then compounds 2 and 3 (each within the scatter of the next).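

In this assay, changing phenyl to 4-fluorophenyl gives a number 10 percentage points higher from compound 2 to compound 3 (within the scatter), so fluoro on this ring, para to a large group, causes no shift that can be told from the scatter. Placing 4-fluorophenyl in place of hydrogen on an aromatic carbon of the shared core gives a number 27 percentage points higher from compound 1 to compound 3 (beyond the scatter), so the rise seen with phenyl is not lost. No measurement here explains either step. The compounds shown leave open how an amine or a carboxylic acid at this same place on the ring would read.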